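Series notes: aryl replacement from compound 3 to compound 4

The compounds below may be only part of what the source reports. "The series", "measured", "known", "first", "only" and "open" are said of these compounds alone.

Measured in a functional assay on SGC-7901 cells (Homo sapiens) for antiproliferative activity, read by MTT assay, with a stated time of 48 h; on this read-out lower numbers stand for stronger inhibition and higher numbers for weaker inhibition:
Compound 1 `COc1cc(OC)c2c(=O)c(OCCCCOc3ccccc3/C=C/C(=O)/C=C/c3ccco3)c(-c3cc(OC)c(OC)c(OC)c3)oc2c1` gives 8980 nM.
Compound 2 `COc1cc(OC)c2c(=O)c(OCCCCOc3ccccc3/C=C/C(=O)/C=C/c3ccc(Cl)cc3)c(-c3cc(OC)c(OC)c(OC)c3)oc2c1` gives 9150 nM.
Compound 3 `COc1cc(OC)c2c(=O)c(OCCCCOc3ccccc3/C=C/C(=O)/C=C/c3cccs3)c(-c3cc(OC)c(OC)c(OC)c3)oc2c1` gives 26500 nM.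

Compound 3 stands at the highest number of the three, separated from both others beyond the scatter: a 3.0-fold higher number from compound 1 to compound 3 (0.47 log units; beyond the scatter) and a 2.9-fold higher number from compound 2 to compound 3 (0.46 log units; beyond the scatter). Compound 4 `COc1cc(OC)c2c(=O)c(OCCCCOc3ccccc3/C=C/C(=O)/C=C/c3cccc([N+](=O)[O-])c3)c(-c3cc(OC)c(OC)c(OC)c3)oc2c1` differs from compound 3 by 3-nitrophenyl in place of thiophen-2-yl on a double-bonded chain carbon bound to a double-bonded chain carbon. The step that bears most directly on this is the reverse of a 2.9-fold higher number from compound 2 to compound 3 (0.46 log units; beyond the scatter), a six-membered carbon ring in place of the five-membered one; between the two six- and five-membered rings of compound 1 and compound 2 the difference was negligible, a 1.0-fold higher number from compound 1 to compound 2 (0.01 log units; within the scatter). A modest lowering of the number in this assay is therefore expected. Compound 4 is expected near 10000 nM, range 4000 nM to 25000 nM. This corresponds to an expected step of a 2.7-fold lower number from compound 3 to compound 4 (0.42 log units; beyond the scatter).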

Compound 4, half-maximal inhibitory concentration: 4030 nM
The estimate for compound 4 lay 2.5-fold (0.39 log units) above the measured number; low and high end bracket the measured number.
By their numbers in this assay, from the lowest: compound 4; then compounds 1 and 2 (each within the scatter of the next); then compound 3.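

In this assay, 3-nitrophenyl on this double-bonded chain carbon gives the lowest number of the four compounds, with all three steps beyond the scatter (a 6.6-fold lower number from compound 3 to compound 4 (0.82 log units; beyond the scatter)) (a 2.3-fold lower number from compound 2 to compound 4 (0.36 log units; beyond the scatter)) (a 2.2-fold lower number from compound 1 to compound 4 (0.35 log units; beyond the scatter)). The earlier compounds shown here showed no separation between 4-chlorophenyl and furan-2-yl; this result shows that two six-membered aromatic rings of carbon only can differ here, so ring size alone does not set the number.

Going by these compounds, it remains open whether the lower number follows the nitro group itself or where it sits on the ring, and whether an amino group on the phenyl ring would keep it. No measurement shown gives a reason for these steps.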